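The source may hold more compounds than are shown below. What is called first, only, known or untested is meant among the compounds shown, and "the series" means these compounds.

Measured so far:
- compound 1 `CCCN1CCN(c2ccc(S(=O)(=O)Oc3cc(Cl)c(Cl)cc3Cl)cc2)C1=O` gives 13000 nM
- compound 2 `CCCN1CCN(c2ccc(S(=O)(=O)Oc3cccc(C)c3)cc2)C1=O` gives 86000 nM
- compound 3 `CCCN1CCN(c2ccc(S(=O)(=O)Oc3cccc(F)c3)cc2)C1=O` gives 24000 nM

In a functional assay on MCF7 cells (Homo sapiens) for antiproliferative activity, read by sulforhodamine B assay, with a stated time of 48 h (on this read-out lower numbers stand for stronger inhibition and higher numbers for weaker inhibition), compound 3 gives 24000 nM. It cannot be separated from compound 1, with a 1.8-fold higher number from compound 1 to compound 3 (0.27 log units; within the scatter). It stands clearly apart from compound 2, with a 3.6-fold lower number from compound 2 to compound 3 (0.55 log units; beyond the scatter).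

The next compound is compound 4 `CCCN1CCN(c2ccc(S(=O)(=O)Oc3ccc(F)cc3)cc2)C1=O`, with the change (4-fluorophenyl in place of 3-fluorophenyl on an oxygen), that is, 4-fluorophenyl in place of 3-fluorophenyl on an oxygen. Among the measured compounds shown here, no measured pair isolates a change of this kind, so the evidence is only indirect. The other changes to the group on this oxygen give a 6.6-fold higher number from compound 1 to compound 2 (0.82 log units; beyond the scatter) and the two steps above. The largest of these replaces one group with a different one, whereas here the same atoms are kept and only joined differently. As far as these compounds go, no step beyond the scatter is therefore expected in this assay, and the direction remains open. The expected step is a 1.2-fold higher number from compound 3 to compound 4 (0.07 log units; within the scatter). The estimate for compound 4 is 28000 nM, with an expected range from 12000 nM to 65000 nM.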

Compound 4, half-maximal inhibitory concentration: 33000 nM
Beside the measured number, compound 4's estimate is 1.2-fold (0.07 log units) below it; the measured number falls inside the stated range.
By their numbers in this assay, from the lowest: compounds 1, 3 and 4 (each within the scatter of the next, the first and the last beyond it); then compound 2.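

Among the compounds shown here, exchanging 3-fluorophenyl for 4-fluorophenyl on the oxygen bound to the sulfonyl sulfur gives the first direct reading of this swap, and in this assay the two compounds cannot be separated, with a 1.4-fold higher number from compound 3 to compound 4 (0.14 log units; within the scatter). The 4-fluorophenyl group nevertheless stands apart from both other groups at this oxygen, with a 2.6-fold lower number from compound 2 to compound 4 (0.42 log units; beyond the scatter) and a 2.5-fold higher number from compound 1 to compound 4 (0.40 log units; beyond the scatter), whereas compound 3 could not be separated from compound 1, so these four compounds form no clean ranking of the fluorophenyl groups against 2,4,5-trichlorophenyl. No measurement is available that would account for any of these differences.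

Still open, as far as these compounds go, is whether an amine or a carboxylic acid on the phenyl ring at this oxygen would move the number beyond the scatter. Also open, from the compounds shown here alone, is how a longer chain in place of the propyl group on the shared core would read.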